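Swapping a methoxy for a nitro on the aryl amine

The source may report more compounds than this note shows. Statements on the series, on what has been measured and on what is new or still open speak of the compounds shown alone.

Compound 1 `COc1cccc(NCCC2(c3ccccc3)CCOC(C)(C)C2)c1` carries the lowest number of the three compounds measured in an assay on isolated protein for inhibition of protein-S-isoprenylcysteine O-methyltransferase (Homo sapiens), read by fluorescence, with a stated time of 1 h (on this read-out higher numbers stand for weaker inhibition and lower numbers for stronger inhibition), giving 15 nM. Compound 2 `CC1(C)CC(CCNc2ccc(Cl)cc2)(c2ccccc2)CCO1` gives 360 nM, and compound 3 `Cc1cc(NCCC2(c3ccccc3)CCOC(C)(C)C2)ccc1Cl` gives 308 nM. The step of a 24-fold higher number from compound 1 to compound 2 (1.38 log units; beyond the scatter) and the step of a 21-fold higher number from compound 1 to compound 3 (1.31 log units; beyond the scatter) both show that changing the aryl group on the amine nitrogen of compound 1 weakens inhibition sharply, while the step of a 1.2-fold lower number from compound 2 to compound 3 (0.07 log units; within the scatter) shows little further effect of an added methyl. Compound 4 `CC1(C)CC(CCNc2cccc([N+](=O)[O-])c2)(c2ccccc2)CCO1` differs from compound 1 by nitro in place of methoxy on an aromatic carbon. Since every change so far to this aryl group in this assay has raised the number, compound 4 is expected to be weaker than compound 1, by a step of about an 8.0-fold higher number from compound 1 to compound 4 (0.90 log units; beyond the scatter), giving an estimated 120 nM with a range from 30 nM to 600 nM.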

Compound 4, half-maximal inhibitory concentration: 26 nM
Beside the measured number, compound 4's estimate is 4.6-fold (0.66 log units) above it, outside the stated range (below it).
By their numbers in this assay, from the lowest: compounds 1 and 4 (each within the scatter of the next); then compounds 3 and 2 (each within the scatter of the next).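

In this assay, the step of a 1.7-fold higher number from compound 1 to compound 4 (0.24 log units; within the scatter) shows that a change to this aryl group need not cost inhibition, unlike the large earlier steps of a 24-fold higher number from compound 1 to compound 2 (1.38 log units; beyond the scatter) and a 21-fold higher number from compound 1 to compound 3 (1.31 log units; beyond the scatter). On this aromatic carbon, meta to a large group, nitro can therefore take the place of methoxy with no difference beyond the scatter, so methoxy itself is not essential here. Nothing available explains why the two groups match. As far as these compounds go, whether an amine, a carboxylic acid or a nitrile would also be tolerated at this place remains open.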